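The compounds below may be only part of what the source reports. "The series", "measured", "known", "first", "only" and "open" are said of these compounds alone.

Compound 3 `Cn1c(Sc2c(F)cc(C(=O)NO)cc2F)nnc1-c1cccnn1` is one of three close analogues on the shared core. In an ADME assay on 697 cells (Homo sapiens) for cytotoxicity, with a stated time of 48 h (on this read-out lower numbers stand for stronger inhibition and higher numbers for weaker inhibition), compound 3 gives > 1000 nM, which is a limit of the assay rather than a number. Compound 1 `Cc1cc(-c2nnc(Sc3c(F)cc(C(=O)NO)cc3F)n2C)nn1C` gives > 1000 nM, likewise a limit. Compound 2 `Cn1c(Sc2c(F)cc(C(=O)NO)cc2F)nnc1-c1ncccc1F` gives > 1000 nM, also a limit. Accordingly a step that the two limits leave unreadable from compound 1 to compound 2, a step that the two limits leave unreadable from compound 1 to compound 3 and a step that the two limits leave unreadable from compound 2 to compound 3; all three values sit at the limit of > 1000 nM in this assay, at which 3 of the 3 values shown sit. Compound 4 `Cn1c(Sc2c(F)cc(C(=O)NO)cc2F)nnc1-c1cccs1` has not yet been measured; it differs from compound 3 by thiophen-2-yl in place of pyridazin-3-yl on an aromatic carbon. For the measured compounds named here, none of the measured steps can be sized, so no step beyond the scatter is expected in this assay, and compound 4 is expected to remain at the limit. The estimate for compound 4 is 3000 nM, with a range from 1000 nM to 10000 nM. That estimate means an expected step that the limit leaves unreadable from compound 3 to compound 4.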

Compound 4, half-maximal inhibitory concentration: > 1000 nM
Compound 4 was reported as a limit; the forecaster's own chance of this, stated with the estimate: 85%; the middle value does not contradict the limit.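

The steps from compound 1, compound 2 and compound 3 to compound 4 cannot be read in this assay, because each compound is reported only as a limit: the limit of > 1000 nM in this assay, at which 4 of the 4 values shown sit.

The compounds shown leave open whether the groups at this position differ at all in this assay.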